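From Fluoro to Hydrogen on the Aromatic Ring

A few compounds are considered here, and "the series" means these few. Any claim that something is new, unique, unknown or untested is made for them only; others in the source may bear on it.

For the measured compounds named here, in a functional assay on the whole organism with Mus musculus as the target (on this read-out lower numbers stand for an effect already at smaller amounts and higher numbers for an effect only at larger amounts of compound), compound 1 `O=C1CCC2(c3ccc(F)cc3)OCCCN12` gives 50 mg/kg, the lowest of the two numbers known. Compound 2 `COc1ccc(C23CCC(=O)N2CCCO3)cc1` gives 139 mg/kg in this assay. For compound 3 `Cc1ccc(C23CCC(=O)N2CCCO3)c(C)c1` only a limit is known in this assay, < 150 mg/kg. The measured step from compound 1 to compound 2 is a 2.8-fold higher number from compound 1 to compound 2 (0.44 log units; beyond the scatter). Compound 4 `O=C1CCC2(c3ccccc3)OCCCN12` carries hydrogen in place of fluoro on an aromatic carbon. Going by the values given here, no measured step removes a substituent from the aromatic ring altogether; the one comparison on that ring is modest in size, so the number for compound 4 in this assay is expected to move little, if at all, beyond the scatter. The estimate for compound 4 is 70 mg/kg, between 30 mg/kg and 160 mg/kg. This amounts to an expected step of a 1.4-fold higher number from compound 1 to compound 4 (0.15 log units; within the scatter).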

Compound 4, dose for half-maximal effect: 169 mg/kg
Compound 4: middle estimate off by 2.4-fold (0.38 log units), on the low side, outside the stated range (above it).
By their numbers in this assay, from the lowest: compound 1; then compounds 2 and 4 (each within the scatter of the next).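

In this assay, hydrogen in place of fluoro on the aromatic carbon para to a large group gives a 3.4-fold higher number from compound 1 to compound 4 (0.53 log units; beyond the scatter), so the fluoro itself matters at this place and a bare ring does not hold the number of compound 1. Hydrogen in place of methoxy gives a 1.2-fold higher number from compound 2 to compound 4 (0.08 log units; within the scatter), so these two groups cannot be told apart here, and among the three groups compared only fluoro stands apart. Nothing among the data given accounts for this difference. The compounds shown leave open whether chloro or trifluoromethyl at this place would match fluoro.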